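Moving the Fluoro Around the Phenyl Ring

This account rests on a few compounds, and the source may have more. Where it says the series, first, only, none or still open, it means among the compounds named here.

Measured so far:
compound 1, `c1ccc(-c2cn3ccnc3c(-c3ccc4ncn(C5CCCCC5)c4c3)n2)cc1`, 37.3%
compound 2, `Fc1ccc(-c2cn3ccnc3c(-c3ccc4ncn(C5CCCCC5)c4c3)n2)cc1`, 7.94%

In a functional assay on U-251 cells (Homo sapiens) for inhibition, read by sulforhodamine B assay, with a stated time of 48 h, tested at 10 uM (on this read-out lower numbers stand for less inhibition and higher numbers for more inhibition at the one concentration tested (going by the name of the read-out)), compound 1 gives 37.3%, and compound 2 gives 7.94%. Going by the values given here, compound 2 therefore holds the lower of the two numbers, with compound 1 as its only neighbour, and the gap between them is beyond the scatter. Among the compounds with values here, the single measured step is a number 29.4 percentage points lower from compound 1 to compound 2 (beyond the scatter).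

Compound 3, `Fc1ccccc1-c1cn2ccnc2c(-c2ccc3ncn(C4CCCCC4)c3c2)n1`, has not been measured. It differs from compound 2 by 2-fluorophenyl in place of 4-fluorophenyl on an aromatic carbon. Within the data shown here, the one step known so far concerns adding a fluoro to a bare phenyl, not shifting a fluoro already present, so it bears on the new step only indirectly: compound 1 and compound 2 bracket the outcomes that have been seen, and a relocated fluoro might restore some of what compound 1 shows or keep what compound 2 shows. The direction is therefore uncertain, and the expected step is a number 10.1 percentage points higher from compound 2 to compound 3 (beyond the scatter). Compound 3 is estimated to give 18%, with a range from 0% to 42%.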

Compound 3, a percentage reported as inhibition, at one concentration (the size of the read-out at that concentration, not a potency): 11.4%
For compound 3 the middle estimate is 6.6 percentage points above the measured one; the measured number falls inside the stated range.
By their numbers in this assay, from the lowest: compounds 2 and 3 (each within the scatter of the next); then compound 1.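

In this assay, moving the fluoro around the phenyl ring gives a number 3.5 percentage points higher from compound 2 to compound 3 (within the scatter), so 2-fluorophenyl and 4-fluorophenyl cannot be told apart on this read-out when attached to this aromatic carbon of the shared core. The comparison with the bare phenyl now has a second fluorinated example, a number 25.9 percentage points lower from compound 1 to compound 3 (beyond the scatter), which shows that the lower number seen with compound 2 is not confined to the 4-fluorophenyl compound: both fluorinated compounds shown stand apart from compound 1, and neither goes against this. No independent measurement is available to explain this result.

On these data alone, what remains open is whether this lower number belongs to the fluoro itself or would also appear with a different group on the phenyl ring, such as a chloro, a methoxy or an amine. Each compound is also described at only one concentration, so these numbers leave open how the compounds would compare across a range of concentrations.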